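One Methyl Added Twice on a Shared Core

This account rests on a few compounds, and the source may have more. Where it says the series, first, only, none or still open, it means among the compounds named here.

Compound 1 `COc1ccc(CN(C(=O)CSC(=S)N2CCN(C)CC2)c2cc(OC)c(OC)c(OC)c2)cc1` and compound 2 `CCN1CCN(C(=S)SCC(=O)N(Cc2ccc(OC)cc2)c2cc(OC)c(OC)c(OC)c2)CC1` differ only by methyl in place of hydrogen on a saturated chain carbon bound to an amine nitrogen in a ring. In a functional assay on MGC-803 cells (Homo sapiens) for inhibition, read by CCK-8 assay, with a stated time of 48 h (on this read-out higher numbers stand for weaker inhibition and lower numbers for stronger inhibition), compound 1 gives 1280 nM, while compound 2 gives 9890 nM, so the change produced a 7.7-fold higher number from compound 1 to compound 2 (0.89 log units; beyond the scatter). Compound 3 `COc1ccc(CN(C(=O)CSC(=S)N2CCN(C)CC2)c2cc(OC)c(OC)c(OC)c2)cc1O` differs from compound 1 by hydroxy in place of hydrogen on an aromatic carbon. In this assay compound 3 gives 860 nM, which amounts to a 1.5-fold lower number from compound 1 to compound 3 (0.17 log units; within the scatter), and compound 3 cannot be set apart from compound 1 on that basis. Compound 4 `CCN1CCN(C(=S)SCC(=O)N(Cc2ccc(OC)c(O)c2)c2cc(OC)c(OC)c(OC)c2)CC1` has not yet been measured. It differs from compound 3 by methyl in place of hydrogen on a saturated chain carbon bound to an amine nitrogen in a ring, at the same place as the change from compound 1 to compound 2, so this is the same change made a second time, now on the core that carries the hydroxy group. The expectation for compound 4 rests on compound 3 at 860 nM and on the earlier step of a 7.7-fold higher number from compound 1 to compound 2 (0.89 log units; beyond the scatter). Compound 4 is therefore expected to come in at about 6600 nM, with a range from 2500 nM to 18000 nM, an expected step of a 7.7-fold higher number from compound 3 to compound 4 (0.89 log units; beyond the scatter) in this assay.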

Compound 4, half-maximal inhibitory concentration: 380 nM
Compound 4: the middle estimate sits 17-fold (1.24 log units) above what was measured; measured number below the stated range.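

On the core that carries the hydroxy group, the change from 4-methylpiperazin-1-yl to 4-ethylpiperazin-1-yl gave a 2.3-fold lower number from compound 3 to compound 4 (0.35 log units; beyond the scatter) in this assay, so the step seen on the core of compound 1 did not carry over in direction or in size: the same change on two cores in this assay, a 7.7-fold higher number (0.89 log units; beyond the scatter) from compound 1 to compound 2 and a 2.3-fold lower number (0.35 log units; beyond the scatter) from compound 3 to compound 4, 17-fold (1.24 log units) apart, beyond the scatter of two such steps

Read the other way, hydroxy in place of hydrogen on an aromatic carbon gave a 26-fold lower number from compound 2 to compound 4 (1.42 log units; beyond the scatter) on the core with the ethyl group, so this step too depended on the core that received it: the same change on two cores in this assay, a 1.5-fold lower number (0.17 log units; within the scatter) from compound 1 to compound 3 and a 26-fold lower number (1.42 log units; beyond the scatter) from compound 2 to compound 4, 17-fold (1.24 log units) apart, beyond the scatter of two such steps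

The two changes therefore do not add independently in these four compounds, but this does not show why they interact or whether the same would hold on any other core, as each comparison rests on a single pair of steps.

The compounds shown leave open whether the reversal is particular to ethyl or would continue with a longer chain such as propyl. They also leave open whether an amine or a fluorine in place of the hydroxy group would pair with ethyl in the same way.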